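A few compounds are considered here, and "the series" means these few. Any claim that something is new, unique, unknown or untested is made for them only; others in the source may bear on it.

Compound 1 `O=C(Nc1ccc(-c2ccccn2)cc1)C1CCCN(Cc2ccc(F)c(F)c2)C1` gives 9000 nM
Compound 2 `O=C(Nc1ccc(-c2ccn[nH]2)cc1)C1CCCN(Cc2ccc(F)c(F)c2)C1` gives 520 nM

In a functional assay on A-375 cells (Homo sapiens) for antiproliferative activity (a higher number here means a weaker inhibitor, a lower number a stronger inhibitor), compound 2 holds the lower of the two numbers, at 520 nM, while compound 1 gives 9000 nM. For the measured compounds named here, the only measured step is large and beyond the scatter: a 17-fold lower number from compound 1 to compound 2 (1.24 log units; beyond the scatter), with 1H-pyrazol-5-yl in place of pyridin-2-yl on an aromatic carbon.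

Compound 3 `O=C(Nc1ccc(-c2ccc[nH]2)cc1)C1CCCN(Cc2ccc(F)c(F)c2)C1` has not yet been measured. It changes the same place: 1H-pyrrol-2-yl in place of 1H-pyrazol-5-yl on an aromatic carbon. Here 1H-pyrrol-2-yl takes the place of 1H-pyrazol-5-yl on an aromatic carbon. The five-membered aromatic ring and the hydrogen-bond donor remain, but the hydrogen-bond acceptor does not.

The measured step bears on this only indirectly, since it did not involve the entering group. A much smaller step is therefore expected in this assay, probably towards a somewhat higher number. The expected change is a 1.7-fold higher number from compound 2 to compound 3 (0.24 log units; within the scatter). For compound 3 the estimated value is 900 nM, with an expected range from 250 nM to 3500 nM.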

Compound 3, half-maximal inhibitory concentration: 360 nM
Compound 3: the middle estimate sits 2.5-fold (0.40 log units) above what was measured, within the range that was stated.
By their numbers in this assay, from the lowest: compounds 3 and 2 (each within the scatter of the next); then compound 1.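

In this assay, 1H-pyrrol-2-yl in place of 1H-pyrazol-5-yl gives a 1.4-fold lower number from compound 2 to compound 3 (0.16 log units; within the scatter), so losing the hydrogen-bond acceptor of the five-membered ring makes no readable difference at this position, para to a large group. Set against pyridin-2-yl, the same group gives a 25-fold lower number from compound 1 to compound 3 (1.40 log units; beyond the scatter), which shows that the large step seen with 1H-pyrazol-5-yl does not depend on that group's second ring nitrogen. Nothing measured here gives a reason for this result.

Both five-membered groups carry a hydrogen-bond donor, so the compounds shown cannot say whether that donor matters. As far as these compounds go, a furan-2-yl or 1-methyl-1H-pyrrol-2-yl group at this position would address that question, and how a carboxylic acid or an amine would fare there also remains open.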